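Nitro to methoxy: estimating compound 3

The source may report more compounds than this note shows. Statements on the series, on what has been measured and on what is new or still open speak of the compounds shown alone.

Among the compounds with values here, compound 2 `O=C(Nc1cccc([N+](=O)[O-])c1)C(Cl)Cl` holds the lowest number measured so far in a functional assay on A549 cells (Homo sapiens) for antiproliferative activity, read by MTT assay, with a stated time of 72 h (a lower number here means a stronger inhibitor, a higher number a weaker inhibitor), giving 18000 nM. Compound 1 `O=C(Nc1ccccc1)C(Cl)Cl`, the unsubstituted parent, gives 130000 nM. Within the data shown here, the only known step is a 7.2-fold lower number from compound 1 to compound 2 (0.86 log units; beyond the scatter). Compound 3 `COc1cccc(NC(=O)C(Cl)Cl)c1` alters compound 2 by methoxy in place of nitro on an aromatic carbon. Among the measured compounds shown here, no measured step covers a methoxy group at this position, so the nitro-for-hydrogen step is the sole guide: it shows this position matters, not how methoxy compares with nitro. Compound 3 is expected to fall between the two measured values, estimated at 60000 nM (range 20000 nM to 180000 nM). The expected step is a 3.3-fold higher number from compound 2 to compound 3 (0.52 log units; beyond the scatter).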

Compound 3, half-maximal inhibitory concentration: 25800 nM
Estimate against measurement, compound 3: 2.3-fold (0.37 log units) above; the range from low to high includes it.
By their numbers in this assay, from the lowest: compounds 2 and 3 (each within the scatter of the next); then compound 1.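

In this assay, methoxy in place of nitro on this aromatic carbon gives a 1.4-fold higher number from compound 2 to compound 3 (0.16 log units; within the scatter) and so does not separate the two groups. Methoxy in place of hydrogen gives a 5.0-fold lower number from compound 1 to compound 3 (0.70 log units; beyond the scatter) and shows that the step away from the unsubstituted parent is not confined to nitro. Nothing available explains why these two groups read alike here.

Still open, from the compounds shown here alone, is whether an amine, a carboxylic acid or a longer chain on this carbon would read like methoxy and nitro or differ from them.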